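Methylsulfanyl for octyloxy on the shared core

A few compounds are considered here, and "the series" means these few. Any claim that something is new, unique, unknown or untested is made for them only; others in the source may bear on it.

Compound 1 `CCCCCCCCOc1nc(N)nc2c1ncn2/C=C1/CC1(CO)CO` gives > 20000 nM in an ADME assay on CCRF-HSB-2 cells (Homo sapiens) for cytotoxicity, with a stated time of 7 days (on this read-out higher numbers stand for lower toxicity in this test and lower numbers for higher toxicity in this test), a limit of the assay.
Compound 2 `CC(C)CNc1nc(N)nc2c1ncn2/C=C1/CC1(CO)CO` gives > 20000 nM in this assay, again a limit.
Compound 3 `Nc1nc(OCC(F)(F)F)c2ncn(/C=C3/CC3(CO)CO)c2n1` gives > 20000 nM in this assay, also a limit.

Among the measured compounds shown here, compound 1 thus stands at no number in this assay but only at a limit, the same one that holds for every value so far: the limit of > 20000 nM in this assay, at which 3 of the 3 values shown sit. The change to compound 4 `CSc1nc(N)nc2c1ncn2/C=C1/CC1(CO)CO` is methylsulfanyl in place of octyloxy on an aromatic carbon. The measured steps that bear on a change on this aromatic carbon are a step that the two limits leave unreadable from compound 1 to compound 2 and a step that the two limits leave unreadable from compound 1 to compound 3, and between the other two a step that the two limits leave unreadable from compound 2 to compound 3. Each of them is unreadable, both ends sitting at the same limit, so neither a size nor a direction can be taken from them. Three different groups on that aromatic carbon, octyloxy, isobutylamino and 2,2,2-trifluoroethoxy, have all left the value at the limit. Compound 4 is therefore expected to reach the limit too, with an estimated 30000 nM and a range of 15000 nM to 100000 nM. The expected step that the limit leaves unreadable from compound 1 to compound 4 is estimated to stay within the scatter.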

Compound 4, half-maximal cytotoxic concentration: > 100000 nM
Compound 4: no number, only a limit (the forecaster's own chance of this, stated with the estimate: 85%); middle value at least 3.3-fold (0.52 log units) away from the limit.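

Among the compounds shown here, compound 4 stands at a limit, as do compound 1, compound 2 and compound 3, so no step from any of them to compound 4 can be read in this assay. The compounds shown leave open whether the group on this aromatic carbon affects cytotoxicity at all.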